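Swapping methoxy for chloro on a sulfonyl-bearing core

A few compounds are considered here, and "the series" means these few. Any claim that something is new, unique, unknown or untested is made for them only; others in the source may bear on it.

Measured compounds:
- compound 1, `COc1ccc(-c2c(S(=O)(=O)c3ccc(C)c(F)c3)cnc3c(F)cccc23)cc1`: 3.27 mL/min
- compound 2, `COc1ccc(-c2c(S(=O)(=O)c3cc(Cl)cc(Cl)c3)cnc3c(F)cccc23)cc1`: 2.11 mL/min

In an ADME assay on microsomes from liver (Homo sapiens) for metabolic stability, tested at 2.5 uM (on this read-out lower numbers stand for slow clearance and higher numbers for fast clearance), compound 1 gives 3.27 mL/min, the highest of the two numbers shown. Among the compounds with values here, its only neighbour is compound 2, and the step of a 1.5-fold lower number from compound 1 to compound 2 (0.19 log units; within the scatter), so the two compounds cannot be told apart on this read-out.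

The unmeasured compound 3, `Cc1ccc(S(=O)(=O)c2cnc3c(F)cccc3c2-c2ccc(Cl)cc2)cc1F`, differs from compound 1 by chloro in place of methoxy on an aromatic carbon. Within the data shown here, the one measured step, from compound 1 to compound 2, changes a different part of the molecule, the group on the sulfonyl sulfur, so no measured step bears directly on this change. With nothing to point either way, the expectation is a step no larger than the scatter, a 1.1-fold lower number from compound 1 to compound 3 (0.04 log units; within the scatter). Compound 3 is therefore estimated at 3 mL/min in this assay, within a range of 1.5 mL/min to 6 mL/min.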

Compound 3, intrinsic clearance in a liver preparation (reported as CLH), per the amount of preparation that the assay uses: 2.2 mL/min
Compound 3: middle estimate off by 1.4-fold (0.13 log units), on the high side, and the stated range covers the measured number.
By their numbers in this assay, from the lowest: compounds 2, 3 and 1 (each within the scatter of the next).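

Within the data shown here, the earlier compounds spoke only about the group on the sulfonyl sulfur, whereas compound 3 gives the first reading at the other end of the molecule, on the aromatic ring that carries the methoxy. In this assay, going from 4-methoxyphenyl to 4-chlorophenyl gives a 1.5-fold lower number from compound 1 to compound 3 (0.17 log units; within the scatter), so at this position chloro and methoxy cannot be told apart on this read-out. Nothing available here offers an explanation for this outcome.

Still open, going by these compounds, is whether a different kind of group at the same position, such as an amine or a carboxylic acid, would shift the number beyond the scatter. Also open, on these data alone, is whether the same swap would read alike with the 3,5-dichlorophenyl group of compound 2 on the sulfonyl sulfur.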